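The compounds below may be only part of what the source reports. "The series", "measured", "known", "first", "only" and "open" are said of these compounds alone.

Cytotoxicity toward a human lung fibroblast line was measured in an ADME assay on WI-38 cells (Homo sapiens) for cytotoxicity, read by MTT assay, with a stated time of 72 h; a lower number here means a stronger inhibitor, a higher number a weaker inhibitor. Three compounds share one core and differ only in the group carried on that core. Compound 1 `O=C(NC/C=C\Cn1cc(F)c(=O)[nH]c1=O)c1ccccc1` carries a fluoro there, and in this assay compound 1 reaches only the limit > 100000 nM, which is a limit of the assay and not a number. Compound 3 `O=C(NC/C=C\Cn1cc(C(F)(F)F)c(=O)[nH]c1=O)c1ccccc1` carries a trifluoromethyl, and compound 3 likewise stops at the limit > 100000 nM. Among the compounds with values here, compound 2 `Cc1cn(C/C=C\CNC(=O)c2ccccc2)c(=O)[nH]c1=O` carries a methyl, and compound 2 gives 4300 nM, the only true number among the three; the step of an at least 23-fold lower number from compound 1 to compound 2 (1.36 log units; beyond the scatter) and the step of an at least 23-fold higher number from compound 2 to compound 3 (1.36 log units; beyond the scatter) both lie beyond the scatter, as underlined by the limit of > 100000 nM in this assay, at which 2 of the 3 values shown sit.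

Compound 4 `Cc1cn(C/C=C\CNC(=O)c2ccc(F)cc2)c(=O)[nH]c1=O` keeps the methyl on the core and instead alters the outer ring: fluoro in place of hydrogen on an aromatic carbon. Within the data shown here, no measured step touches this outer ring; every measured change sits on the core. So nothing among the measured steps points either way, and the expectation is a step of a 1.0-fold higher number from compound 2 to compound 4 (0.02 log units; within the scatter), within the scatter. Compound 4 is therefore estimated at 4500 nM, with a range from 1500 nM to 15000 nM.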

Compound 4, half-maximal inhibitory concentration: 100 nM
Estimate against measurement, compound 4: 45-fold (1.65 log units) above, and the stated range ends above it.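

Until now every measured change sat on the shared core, so the outer ring was an unknown. In this assay, putting fluoro in place of hydrogen on that ring, para to a large group, gives a 43-fold lower number from compound 2 to compound 4 (1.63 log units; beyond the scatter) and so shows that this position is far from silent: even the smallest phenyl to 4-fluorophenyl swap can shift the number strongly, and the outcome in these cells depends on both ends of the molecule, not only on the group carried by the core. The compounds shown measure the outcome of this swap but offer nothing that accounts for it.

On these data alone, this is a single pair with methyl on the core, so it is open whether 4-fluorophenyl would act the same way alongside the fluoro or the trifluoromethyl on the core. As far as these compounds go, it is also open whether the effect belongs to fluoro itself or would appear with another group in the same place, such as a chloro, a methoxy or an amine, and whether fluoro elsewhere on the outer ring would do the same.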